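Acetyl in Place of Isopropyl in a Hydrolase Inhibitor Series

The source may hold more compounds than are shown below. What is called first, only, known or untested is meant among the compounds shown, and "the series" means these compounds.

Of the compounds shown here, three sharing a common core have been tested in an assay on a protein complex for inhibition of ubiquitin carboxyl-terminal hydrolase 1/WD repeat-containing protein 48 (Homo sapiens), read by fluorescence; a lower number here means a stronger inhibitor, a higher number a weaker inhibitor. Compound 1 `CC(C)c1ccccc1-c1nccc(NCc2ccc(-c3cccnc3)cc2)n1` gives 150 nM. Compound 2 `Cc1cnc(-c2ccccc2C(C)C)nc1NCc1ccc(-c2cccnc2)cc1` carries a methyl where compound 1 carries hydrogen. Compound 2 gives 70 nM, the lowest of the three numbers; a 2.1-fold lower number from compound 1 to compound 2 (0.33 log units; beyond the scatter). Compound 3 `CC(C)c1ccccc1-c1ncc(N(C)C)c(NCc2ccc(-c3cccnc3)cc2)n1` gives 190 nM; a 1.3-fold higher number from compound 1 to compound 3 (0.10 log units; within the scatter), while a 2.7-fold higher number from compound 2 to compound 3 (0.43 log units; beyond the scatter). Compound 4 `CC(=O)c1ccccc1-c1ncc(C)c(NCc2ccc(-c3cccnc3)cc2)n1` has not yet been measured. It differs from compound 2 in one place: acetyl in place of isopropyl on an aromatic carbon. For the measured compounds named here, none of the measured steps touches that part of the molecule; all three concern the group on an aromatic carbon of the core, so they say nothing direct about exchanging isopropyl for acetyl. Going by the values given here, with no step to lean on, the outcome for compound 4 is uncertain, and a modest step in either direction from compound 2 would not surprise. The expected step is a 2.9-fold higher number from compound 2 to compound 4 (0.46 log units; beyond the scatter). Compound 4 is therefore estimated to give about 200 nM in this assay, within a range of 50 nM to 800 nM.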

Compound 4, half-maximal inhibitory concentration: 8700 nM
Compound 4: middle estimate off by 44-fold (1.64 log units), on the low side, outside the stated range (above it).
By their numbers in this assay, from the lowest: compound 2; then compounds 1 and 3 (each within the scatter of the next); then compound 4.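

The isopropyl of the 2-isopropylphenyl group proves far from interchangeable in this assay: acetyl in its place brings a 120-fold higher number from compound 2 to compound 4 (2.09 log units; beyond the scatter) and so marks a much larger step than any printed among the first three compounds. For the compounds shown here, the earlier steps all concerned another place on the shared core, so this is the first sign of how strongly the result depends on the group ortho to a large group on the ring of carbon only. The exchange keeps the count at three heavy atoms yet adds a hydrogen-bond acceptor and a double bond, and no measurement at hand explains the size of the step.

On these data alone, it remains open whether an ethyl, a methoxy or an amine at this place would stay near isopropyl or fall near acetyl. As far as these compounds go, it is also open whether the same exchange would cost as much with hydrogen or dimethylamino on the core in place of methyl.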